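From 3-carboxy-1,2-oxazol-5-yl to 1-isopropyl-1H-pyrazol-3-yl

The source may hold more compounds than are shown below. What is called first, only, known or untested is meant among the compounds shown, and "the series" means these compounds.

Compound 1 (`CCNC(=O)c1noc(-c2cc(C(C)C)c(O)cc2O)c1-c1cc(CO)no1`) and compound 2 (`CCNC(=O)c1noc(-c2cc(C(C)C)c(O)cc2O)c1-c1cc(C(=O)O)no1`) share one core. In a functional assay on HCT-116 cells (Homo sapiens) for inhibition (a lower number here means a stronger inhibitor, a higher number a weaker inhibitor), compound 1 gives 13 nM as its half-maximal inhibitory concentration. For compound 2 the entry reads "not determined" (no result reported) and offers no number to start from. The change to compound 3 (`CCNC(=O)c1noc(-c2cc(C(C)C)c(O)cc2O)c1-c1ccn(C(C)C)n1`) is 1-isopropyl-1H-pyrazol-3-yl in place of 3-carboxy-1,2-oxazol-5-yl on an aromatic carbon and puts 1-isopropyl-1H-pyrazol-3-yl in place of 3-carboxy-1,2-oxazol-5-yl on an aromatic carbon. Going by the values given here, no measured step gauges this change in this assay so the only anchor is compound 1 (13 nM) and a modest weakening from that value is expected. Compound 3 is estimated at 30 nM with an expected range from 6 nM to 150 nM in this measurement.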

Compound 3, half-maximal inhibitory concentration: 19 nM
The estimate for compound 3 lay 1.6-fold (0.20 log units) above the measured number, and the stated range covers the measured number.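

In this assay, the step of a 1.5-fold higher number from compound 1 to compound 3 (0.16 log units; within the scatter) lies within the scatter, so at this position 1-isopropyl-1H-pyrazol-3-yl serves as well as 3-(hydroxymethyl)-1,2-oxazol-5-yl, and potency does not depend on keeping that ring. The step from compound 2 cannot be read, since compound 2 has no number. Nothing shown here accounts for this result.

The compounds shown leave open how the 3-carboxy-1,2-oxazol-5-yl group itself compares. They also leave open whether an amine or a longer alkyl chain in place of the isopropyl group would hold potency in this assay.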